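Pyrazolo-fused lactams at the zinc-sensing receptor: a ring-carbon swap

The compounds below may be only part of what the source reports. "The series", "measured", "known", "first", "only" and "open" are said of these compounds alone.

Measured so far:
compound 1 `Cc1nn(-c2ncnc3nc[nH]c23)c2c1C(C(=O)NCc1ccc(F)cc1)CC(=O)N2`: 1220 nM
compound 2 `Cc1cc(C)nc(-n2nc(C)c3c2NC(=O)CC3c2ccc(COc3cccc(Cl)c3)cc2)n1`: 3000 nM
compound 3 `Cc1nn(-c2ncnc3nc[nH]c23)c2c1C(c1ccc(OC(C)C)cc1)CC(=O)N2`: 2700 nM

All three were run in a functional assay on HEK293 cells for agonist activity at G-protein coupled receptor 39 (Homo sapiens), read by scintillation proximity assay and inositol phosphate accumulation, with a stated time of 75 min; a higher number here means that more compound is needed for the effect, a lower number that less compound is needed. Compound 3 gives the second-highest number of the three. Its nearest neighbour is compound 2, whose value in this assay lies within the usual scatter of that of compound 3, so no order between these two can be stated. The furthest is compound 1, whose number is lower than that of compound 3 by more than the scatter.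

Compound 4 `Cc1nn(-c2ncnc3nc[nH]c23)c2c1C(NC(=O)c1ccccc1)CC(=O)N2` is not yet measured. It differs from compound 3 in one place: benzamido in place of 4-isopropoxyphenyl on a saturated ring carbon. For the measured compounds named here, no step between measured compounds isolates such a change. Compound 1 carries an amide at the same ring carbon, and its value in this assay is 1220 nM, which is the only hint that an amide there is tolerated. The step of a 1.4-fold lower number from compound 3 to compound 4 (0.13 log units; within the scatter) is therefore expected to be small, towards a lower number, but not with confidence beyond the scatter. For compound 4 the expected value is 2000 nM, with a range from 500 nM to 8000 nM.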

Compound 4, half-maximal effective concentration: 158 nM
Beside the measured number, compound 4's estimate is 13-fold (1.10 log units) above it, outside the stated range (below it).
By their numbers in this assay, from the lowest: compound 4; then compound 1; then compounds 3 and 2 (each within the scatter of the next).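

In this assay this saturated ring carbon proves sensitive to the group it carries: benzamido in place of 4-isopropoxyphenyl brings a large step (a 17-fold lower number from compound 3 to compound 4 (1.23 log units; beyond the scatter)), so an aromatic ring held there does not settle the value by itself. Both groups hold one six-membered aromatic ring of carbon only, and the counted differences are the added hydrogen-bond donor and the double bond outside aromatic rings, which this single step cannot separate. Nothing measured on hand accounts for the size of the step.

Open, on these data alone, is whether the amide hydrogen matters, which a methylated benzamido group would address, while a plain amine at the same ring carbon would test the need for the carbonyl. An acetamido group would show how much depends on the phenyl ring of benzamido.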